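A few compounds are considered here, and "the series" means these few. Any claim that something is new, unique, unknown or untested is made for them only; others in the source may bear on it.

In a functional assay on L1210 cells (Mus musculus) for antiproliferative activity, read by sulforhodamine B assay, with a stated time of 48 h (on this read-out lower numbers stand for stronger inhibition and higher numbers for weaker inhibition), compound 2 `O=C1NCCN1c1ccc(S(=O)(=O)Nc2cccc(Br)c2)cc1` gives 99 nM and compound 1 `Cc1cccc(NS(=O)(=O)c2ccc(N3CCNC3=O)cc2)c1` gives 180 nM, so the two stand level. Compound 3 `Cc1cc(C)cc(NS(=O)(=O)c2ccc(N3CCNC3=O)cc2)c1` has 3,5-dimethylphenyl in place of 3-bromophenyl on a sulfonamide nitrogen. Going by the values given here, the one measured step that bears on this is a 1.8-fold lower number from compound 1 to compound 2 (0.26 log units; within the scatter), which exchanges methyl and bromo on an aromatic carbon. Among the compounds with values here, no measured compound shows what a second methyl does. A step beyond the scatter is therefore not expected, and the estimated step is a 1.3-fold higher number from compound 2 to compound 3 (0.12 log units; within the scatter). The expected value for compound 3 is 130 nM, with an estimated range of 50 nM to 340 nM.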

Compound 3, half-maximal inhibitory concentration: 110 nM
Compound 3: the middle estimate sits 1.2-fold (0.07 log units) above what was measured, and the stated range covers the measured number.
By their numbers in this assay, from the lowest: compounds 2, 3 and 1 (each within the scatter of the next).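

Putting 3,5-dimethylphenyl in place of 3-bromophenyl on the sulfonamide nitrogen gives a 1.1-fold higher number from compound 2 to compound 3 (0.05 log units; within the scatter) and so leaves the two compounds level. Adding a second methyl, as methyl in place of hydrogen on an aromatic carbon, gives a 1.6-fold lower number from compound 1 to compound 3 (0.21 log units; within the scatter) and also stays within the scatter, so this aryl group tolerates both changes without a readable shift. No measurement at hand offers an explanation for these results. Still open, as far as these compounds go, is whether a methoxy group or an amine on this aromatic ring would keep the numbers level, and what a saturated cyclohexyl group would do on the sulfonamide nitrogen.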